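A six-membered ring amine replaces hydrogen on compound 2

This account rests on a few compounds, and the source may have more. Where it says the series, first, only, none or still open, it means among the compounds named here.

Compound 2 `COc1cc[nH]c1/C=C1\C(=O)Nc2ccc([N+](=O)[O-])cc21` carries only hydrogen at the position in question. In a functional assay on MDA-MB-435 cells (Homo sapiens) for antiproliferative activity, read by MTT assay, with a stated time of 5 days (on this read-out higher numbers stand for weaker inhibition and lower numbers for stronger inhibition), compound 2 gives 7460 nM, the highest of the two plain numbers shown. Compound 1 `COc1cc[nH]c1/C=C1\C(=O)Nc2ccc([N+](=O)[O-])c(N3CC[C@H](O)C3)c21` gives 104 nM, and the step of a 72-fold higher number from compound 1 to compound 2 (1.86 log units; beyond the scatter) shows how much is lost when its ring is removed. Compound 3 `COc1cc[nH]c1/C=C1\C(=O)Nc2ccc([N+](=O)[O-])c(N3CCC(N)CC3)c21` sits at a limit of the assay, < 10 nM (the limit of < 10 nM in this assay, at which 1 of the 3 values shown sits). The step of an at least 740-fold lower number from compound 2 to compound 3 (2.87 log units; beyond the scatter) is larger still. Compound 4 `COc1cc[nH]c1/C=C1\C(=O)Nc2ccc([N+](=O)[O-])c(N3CCCC(CO)C3)c21` differs from compound 2 by 3-(hydroxymethyl)piperidin-1-yl in place of hydrogen on an aromatic carbon. Both measured additions of a ring amine at this position gave large gains, so a large drop in this assay is expected for the step of a 150-fold lower number from compound 2 to compound 4 (2.17 log units; beyond the scatter). Compound 4 is therefore estimated at 50 nM, between 10 nM and 300 nM.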

Compound 4, half-maximal inhibitory concentration: 441 nM
Beside the measured number, compound 4's estimate is 8.8-fold (0.95 log units) below it, outside the stated range (above it).
By their numbers in this assay, from the lowest: compound 1; then compound 4; then compound 2. At a limit, below all of these: compound 3.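

A third ring amine also helps at this position, with a 17-fold lower number from compound 2 to compound 4 (1.23 log units; beyond the scatter) and still a large gain. A six-membered ring does not settle the outcome by itself: an at least 44-fold higher number from compound 3 to compound 4 (1.64 log units; beyond the scatter) separates two piperidines, and a 4.2-fold higher number from compound 1 to compound 4 (0.63 log units; beyond the scatter) leaves this piperidine behind the five-membered ring of compound 1. The number for compound 3 is a limit, so that first gap has no fixed size: the limit of < 10 nM in this assay, at which 1 of the 4 values shown sits.
Open, on these data alone, is whether the gap to compound 3 follows the amine or where the substituent sits on the piperidine. A 3-aminopiperidin-1-yl group here would separate the two.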